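The compounds below may be only part of what the source reports. "The series", "measured", "known", "first", "only" and "open" are said of these compounds alone.

Measured so far in an ADME assay on HepG2 2.2.15 cells (Homo sapiens) for cytotoxicity; on this read-out higher numbers stand for lower toxicity in this test and lower numbers for higher toxicity in this test:

compound 1, `Cn1c(=O)c(CCO)c(-c2ccccc2Cl)c2cc(Cl)ccc21`, gives 34000 nM
compound 2, `COCC(=O)OCCc1c(-c2ccccc2Cl)c2cc(Cl)ccc2[nH]c1=O`, gives 74000 nM
compound 3, `CCOCC(=O)OCCc1c(-c2ccccc2Cl)c2cc(Cl)ccc2[nH]c1=O`, gives 130000 nM

Compound 2 stands second highest of the three numbers. Its nearest neighbour is compound 3, with a 1.8-fold higher number from compound 2 to compound 3 (0.24 log units; within the scatter), a difference that stays within the scatter of repeated runs; the furthest is compound 1, whose number lies beyond the scatter below that of compound 2.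

Compound 4, `O=C(OCCc1c(-c2ccccc2Cl)c2cc(Cl)ccc2[nH]c1=O)c1cccs1`, is not yet measured. Against compound 2 the change is thiophen-2-yl in place of methoxymethyl on a carbonyl carbon.

Within the data shown here, only one measured step touches the ester end of the chain, and it is small: a 1.8-fold higher number from compound 2 to compound 3 (0.24 log units; within the scatter). Among the measured compounds shown here, that step alters the same group but by far less than the present exchange of methoxymethyl for thiophen-2-yl, so it gives no firm direction; with no closer precedent, the expected movement in this assay is none beyond the scatter, leaning slightly toward a lower number.

For compound 4 the estimate in this assay is 60000 nM, with a range from 25000 nM to 150000 nM, which means an expected step of a 1.2-fold lower number from compound 2 to compound 4 (0.09 log units; within the scatter).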

Compound 4, half-maximal cytotoxic concentration: > 1700000 nM
Compound 4: a limit, no number; the forecaster's own chance of this, stated with the estimate: 15%; middle value at least 28-fold (1.45 log units) from the limit.
By their numbers in this assay, from the lowest: compound 1; then compounds 2 and 3 (each within the scatter of the next). At a limit, above all of these: compound 4.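

In this assay, the group on the carbonyl carbon can move the read-out much further than the exchange of methoxymethyl for ethoxymethyl indicated, which gave a 1.8-fold higher number from compound 2 to compound 3 (0.24 log units; within the scatter). Thiophen-2-yl gives an at least 22-fold higher number from compound 2 to compound 4 (1.36 log units; beyond the scatter) and an at least 13-fold higher number from compound 3 to compound 4 (1.11 log units; beyond the scatter), both toward lower toxicity in this test. The reading for compound 4 is a limit of the assay and not a number, so the true size of both steps stays unknown: the limit of > 1700000 nM in this assay, at which 1 of the 4 values shown sits.

The compounds shown cannot tell whether this jump belongs to thiophen-2-yl specifically or would also come with another aromatic ring on the carbonyl carbon, such as phenyl or furan-2-yl. They also leave open how a saturated ring such as cyclohexyl or an amine-bearing chain in the same place would read.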